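From tert-butyl to isopropyl on compound 2

The source may hold more compounds than are shown below. What is called first, only, known or untested is meant among the compounds shown, and "the series" means these compounds.

In a functional assay for inhibition, with Rattus norvegicus as the target (on this read-out lower numbers stand for stronger inhibition and higher numbers for weaker inhibition), compound 1 `C[C@@H](/N=c1\c(O)c(O)\c1=N/c1ccc2c[nH]nc2c1)C(C)(C)C` gives 4600 nM and compound 2 `CC(C)(C)/N=c1\c(O)c(O)\c1=N/c1ccc(C#N)cc1` gives 560 nM as the lower number of the two, a gap beyond the scatter. Compound 3 `CC(C)/N=c1\c(O)c(O)\c1=N/c1ccc(C#N)cc1` swaps tert-butyl for isopropyl hydrogen in place of methyl on a saturated chain carbon bound to a double-bonded nitrogen and two saturated chain carbons with hydrogen in place of methyl on a saturated chain carbon bound to a double-bonded nitrogen and two saturated chain carbons. For the measured compounds named here, no measured pair shows this change alone, so the expectation is loose. In this assay a small move toward a higher number is expected, with a 1.8-fold higher number from compound 2 to compound 3 (0.25 log units; within the scatter) staying near the scatter. Compound 3 is estimated at 1000 nM (range 300 nM to 3300 nM).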

Compound 3, half-maximal inhibitory concentration: 13700 nM
Estimate against measurement, compound 3: 14-fold (1.14 log units) below; the measured number lies above the stated range.
By their numbers in this assay, from the lowest: compound 2; then compound 1; then compound 3.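

In this assay, replacing tert-butyl with isopropyl gives a 24-fold higher number from compound 2 to compound 3 (1.39 log units; beyond the scatter). The read-out at this saturated chain carbon is therefore highly sensitive to the loss of a single methyl, far more than a one-carbon difference might suggest. For the compounds shown here, compound 1 and compound 2 differ in more than one place, so this is the first pair to isolate the change, although no available evidence explains the size of the step.

As far as these compounds go, how a cyclopropyl ring or a longer chain such as n-butyl would read at this carbon remains open. So does whether the step carries over to the core of compound 1.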